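Thiophen-2-yl for 4-fluorophenyl: an expected small step

The source may report more compounds than this note shows. Statements on the series, on what has been measured and on what is new or still open speak of the compounds shown alone.

Measured compounds:
compound 1 `c1ccc2c(-c3cn4ccnc4c(-c4ccc5ncn(C6CCCCC6)c5c4)n3)cccc2c1`: 16.5%
compound 2 `Fc1ccc(-c2cn3ccnc3c(-c3ccc4ncn(C5CCCCC5)c4c3)n2)cc1`: 21%

In a functional assay on SNB-75 cells (Homo sapiens) for inhibition, read by sulforhodamine B assay, with a stated time of 48 h, tested at 10 uM (a higher number here means more inhibition at the concentration tested (going by the name of the read-out), a lower number less inhibition), compound 1 gives 16.5% and compound 2 gives 21%. Compound 2 stands highest of the two numbers shown, yet the step of a number 4.5 percentage points higher from compound 1 to compound 2 (within the scatter) lies within the scatter, so the two compounds cannot be ordered on these data.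

Compound 3 `c1csc(-c2cn3ccnc3c(-c3ccc4ncn(C5CCCCC5)c4c3)n2)c1` has not been measured in this assay. It differs from compound 2 in one place: thiophen-2-yl in place of 4-fluorophenyl on an aromatic carbon.

Among the measured compounds shown here, only one measured step exists, naphthalen-1-yl exchanged for 4-fluorophenyl on the same aromatic carbon, and it was a number 4.5 percentage points higher from compound 1 to compound 2 (within the scatter), within the scatter. That step changes the group at the same place as the new one, so it is the step that bears on it; it shows no movement beyond the scatter. The step of a number 3 percentage points lower from compound 2 to compound 3 (within the scatter) is therefore expected to stay within the scatter, with no clear direction. For compound 3 the estimated value is 18%, with a range from 5% to 35%.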

Compound 3, a percentage reported as inhibition, at one concentration (the size of the read-out at that concentration, not a potency): 8.13%
Compound 3: middle estimate off by 9.9 percentage points, on the high side, and the stated range covers the measured number.
By their numbers in this assay, from the lowest: compounds 3, 1 and 2 (each within the scatter of the next, the first and the last beyond it).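

In this assay, among the compounds shown here, this position moves the read-out beyond the scatter for the first time: a number 12.9 percentage points lower from compound 2 to compound 3 (beyond the scatter) is a modest step, whereas the earlier exchange of naphthalen-1-yl for 4-fluorophenyl had left its two compounds unseparated. The change is not a general effect of leaving a six-membered aromatic ring of carbon only, since a number 8.4 percentage points lower from compound 1 to compound 3 (within the scatter) stays within the scatter, so only thiophen-2-yl and 4-fluorophenyl are told apart here. Nothing available explains the step.

The compounds shown leave open whether an unsubstituted phenyl at this carbon would stand with 4-fluorophenyl or with thiophen-2-yl. They also leave open whether an amine or a carboxylic acid on the ring at this position would raise the number clearly above those seen so far.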